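Extending the Amine on a Melanocortin Receptor Ligand

The compounds below may be only part of what the source reports. "The series", "measured", "known", "first", "only" and "open" are said of these compounds alone.

Compound 1 `CCC(C)C(N)c1cc(C(F)(F)F)ccc1N1CCN(C(=O)CCc2ccc(Cl)cc2Cl)CC1` was examined in an assay on HEK293 cells for displacement of a labelled ligand from Melanocortin receptor 4 (Homo sapiens) (on this read-out higher numbers stand for weaker inhibition and lower numbers for stronger inhibition), where compound 1 gives 160 nM. For the measured compounds named here, the only other measured compound, compound 2 `CC(C)C[C@H](N)c1cc(C(F)(F)F)ccc1N1CCN(C(=O)CCc2ccccc2Cl)CC1`, gives 1700 nM in this assay, so compound 1 stands with the lower of the two numbers, and the gap between them lies beyond the usual scatter of repeated measurements. Going by the values given here, compound 2 differs from compound 1 in more than one place, so no single structural step between them can be read off.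

Compound 3 `CCC(C)[C@H](NC[C@H](C)N)c1cc(C(F)(F)F)ccc1N1CCN(C(=O)CCc2ccc(Cl)cc2Cl)CC1` has not yet been measured. It differs from compound 1 in one place: 1-((2-aminopropyl)amino)-2-methylbutyl in place of 1-amino-2-methylbutyl on an aromatic carbon. The primary amine of compound 1 thus becomes a secondary amine carrying a 2-aminopropyl chain, while the remainder of the shared core is unchanged.

Among the compounds with values here, no measured step of this kind is available, so the expectation for compound 3 rests on compound 1 alone, which gives 160 nM in this assay. The step is expected to be a 1.5-fold lower number from compound 1 to compound 3 (0.16 log units; within the scatter), within the scatter rather than beyond it. Compound 3 is therefore estimated at 110 nM, with a range from 30 nM to 450 nM.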

Compound 3, inhibition constant: 89 nM
Beside the measured number, compound 3's estimate is 1.2-fold (0.09 log units) above it, and the stated range covers the measured number.
By their numbers in this assay, from the lowest: compounds 3 and 1 (each within the scatter of the next); then compound 2.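

The step of a 1.8-fold lower number from compound 1 to compound 3 (0.25 log units; within the scatter) shows that in this assay this position, on an aromatic carbon ortho to a large group, accepts a much larger substituent without a change beyond the scatter. The 1-amino-2-methylbutyl group has 6 heavy atoms and no defined stereocentre in compound 1, whereas the 1-((2-aminopropyl)amino)-2-methylbutyl group has 10 heavy atoms, 2 defined stereocentres and a second nitrogen, so the primary amine can carry a 2-aminopropyl chain while the number stays within the scatter of that of compound 1. For the compounds shown here, nothing available here accounts for this outcome, and the single step gives no information on how the added chain acts on the receptor.

The compounds shown leave open whether a shorter 2-aminoethyl chain, a longer 3-aminopropyl chain or a chain ending in a hydroxyl group or a carboxylic acid would give a similar number on the same nitrogen. They also leave open how far the opposite configuration at either stereocentre of the new group, or a tertiary amine in place of the secondary amine, would shift the result.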